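Working notes: methylsulfanyl for ethoxy, compound 2 to compound 4

A few compounds are considered here, and "the series" means these few. Any claim that something is new, unique, unknown or untested is made for them only; others in the source may bear on it.

Measured so far:
Compound 1 `CCOc1ccc(C2C(O)C(=O)N2c2cc(OC)c(OC)c(OC)c2)cc1` gives 15 nM in a functional assay on HT-29 cells (Homo sapiens) for inhibition, read by sulforhodamine B assay, with a stated time of 72 h; a higher number here means a weaker inhibitor, a lower number a stronger inhibitor.
Compound 2 `CCOc1ccc(C2CC(=O)N2c2cc(OC)c(OC)c(OC)c2)cc1` gives 65 nM in this assay.
Compound 3 `C=CC1C(=O)N(c2cc(OC)c(OC)c(OC)c2)C1c1ccc(OCC)cc1` gives 97 nM in this assay.

Compound 2 stands second highest of the three numbers. Its nearest neighbour is compound 3, reached by a 1.5-fold higher number from compound 2 to compound 3 (0.17 log units; within the scatter); its furthest is compound 1, from which it is reached by a 4.3-fold higher number from compound 1 to compound 2 (0.64 log units; beyond the scatter). The third step, a 6.5-fold higher number from compound 1 to compound 3 (0.81 log units; beyond the scatter), also alters the saturated ring carbon only.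

Compound 4 `COc1cc(N2C(=O)CC2c2ccc(SC)cc2)cc(OC)c1OC` differs from compound 2 at the aromatic ring: methylsulfanyl in place of ethoxy on an aromatic carbon. For the measured compounds named here, no measured step touches that ring, so none bears on this change. With nothing to support a shift either way, the expectation in this assay is no step beyond the scatter, no change at the digits printed from compound 2 to compound 4 (within the scatter). Compound 4 is therefore estimated at 65 nM, in the range 25 nM to 170 nM.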

Compound 4, half-maximal inhibitory concentration: 108 nM
Compound 4: the middle estimate sits 1.7-fold (0.22 log units) below what was measured, and the stated range covers the measured number.
By their numbers in this assay, from the lowest: compound 1; then compounds 2, 3 and 4 (each within the scatter of the next).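

In this assay, for the compounds shown here, the change of methylsulfanyl in place of ethoxy gives a 1.7-fold higher number from compound 2 to compound 4 (0.22 log units; within the scatter), the first reading on this aromatic carbon, para to a large group. Within this pair, the position accepts methylsulfanyl with no change beyond the scatter. No supporting measurement bears on this result.

The compounds shown leave open whether hydroxy on the saturated ring carbon would give the same step with methylsulfanyl on the aromatic ring as with ethoxy. They also leave open how an amine or a longer alkoxy chain such as butoxy would read at this aromatic position.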